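Acetyl in place of nitro: from compound 3 to compound 4

A few compounds are considered here, and "the series" means these few. Any claim that something is new, unique, unknown or untested is made for them only; others in the source may bear on it.

Three analogues of the shared core have been examined in a functional assay on MDA-MB-231 cells (Homo sapiens) for inhibition, read by MTT assay, with a stated time of 48 h; on this read-out lower numbers stand for stronger inhibition and higher numbers for weaker inhibition. Compound 1 `O=C1Nc2cc(Br)ccc2/C1=C\c1cccc(OCc2cn(Cc3ccccc3)nn2)c1` carries a bromine on the fused ring; in this assay compound 1 gives "not determined" (no result reported). Compound 2 `O=C1Nc2ccc(F)cc2/C1=C\c1cccc(OCc2cn(Cc3ccccc3)nn2)c1` carries fluoro at the corresponding place; in this assay compound 2 reaches only the limit > 50000 nM. Compound 3 `O=C1Nc2ccc([N+](=O)[O-])cc2/C1=C\c1cccc(OCc2cn(Cc3ccccc3)nn2)c1` carries nitro; in this assay compound 3 also reaches only the limit > 50000 nM. Compound 3 thus stands at the limit, and the step that the two limits leave unreadable from compound 2 to compound 3 cannot be read because of the limit of > 50000 nM in this assay, at which 2 of the 3 values shown sit.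

Compound 4 `CC(=O)c1ccc2c(c1)/C(=C\c1cccc(OCc3cn(Cc4ccccc4)nn3)c1)C(=O)N2` differs from compound 3 by acetyl in place of nitro on an aromatic carbon. Among the measured compounds shown here, the only measured step that bears on this position is the one from compound 2 to compound 3, and its size is not readable. With both neighbouring values at the limit, no movement beyond the scatter can be predicted for this assay. Compound 4 is expected at 60000 nM with a range from 15000 nM to 250000 nM. The expected step is a step that the limit leaves unreadable from compound 3 to compound 4, with a high chance that only a limit is returned.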

Compound 4, half-maximal inhibitory concentration: > 50000 nM
Compound 4 was reported as a limit (the forecaster's own chance of this, stated with the estimate: 70%); the middle value lies beyond the limit too.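

Compound 4 gives no readable step against compound 2 or compound 3, because all three stop at the same limit: the limit of > 50000 nM in this assay, at which 3 of the 4 values shown sit.

The compounds shown leave open how fluoro, nitro and acetyl compare at this place on the shared core in this assay, since none has a single number there.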